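This account rests on a few compounds, and the source may have more. Where it says the series, first, only, none or still open, it means among the compounds named here.

Among the measured compounds shown here, compound 1, with the structure `COc1cc(NC(=O)Nc2cc(Nc3ccc(F)c(Cl)c3)ncn2)cc(OC)c1`, is one of two compounds measured in a functional assay on HCC827 cells (Homo sapiens) for inhibition, read by MTT assay, with a stated time of 48 h, tested at 10 uM (on this read-out higher numbers stand for more inhibition at the one concentration tested (going by the name of the read-out) and lower numbers for less inhibition), where compound 1 gives 53.1%. The other measured compound, compound 2, has the structure `O=C(Nc1cc(Nc2ccc(F)c(Cl)c2)ncn1)Nc1c(Cl)cccc1Cl` and in this assay compound 2 gives 53.7%. The two numbers lie within the usual scatter of each other, so the data so far give no separation between compound 1 and compound 2.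

Compound 3, with the structure `COc1cc(NC(=O)Nc2cc(Nc3ccc(OC)c(C)c3)ncn2)cc(OC)c1`, is not yet measured. It differs from compound 1 in one place: 4-methoxy-3-methylphenyl in place of 3-chloro-4-fluorophenyl on a nitrogen on an aromatic ring. For the measured compounds named here, no measured pair shows this kind of change, so nothing in the data fixes its effect; the step from compound 1 to compound 3 in this assay is expected to be a modest loss, a number 13.1 percentage points lower from compound 1 to compound 3 (beyond the scatter), though a result within the scatter would not be surprising. Compound 3 is therefore estimated to give 40%, with a range from 15% to 65%.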

Compound 3, a percentage reported as inhibition, at one concentration (the size of the read-out at that concentration, not a potency): 48.3%
Compound 3: middle estimate off by 8.3 percentage points, on the low side; the measured number falls inside the stated range.
By their numbers in this assay, from the lowest: compounds 3, 1 and 2 (each within the scatter of the next).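

In this assay, among the compounds shown here, the first step at this position, 4-methoxy-3-methylphenyl in place of 3-chloro-4-fluorophenyl on a nitrogen on an aromatic ring, reads as a number 4.8 percentage points lower from compound 1 to compound 3 (within the scatter) and so gives no separation between the two compounds. Fluorine and chlorine can therefore both be absent from this group, with oxygen and additional carbon present instead, without the result leaving the scatter of compound 1. Nothing measured here accounts for this result.

The compounds shown leave open whether a group of another kind at this position, such as a morpholine or a carboxylic acid on the phenyl ring, would separate from compound 1. They also leave open whether the same exchange would give a similar step on the core of compound 2.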